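The source may hold more compounds than are shown below. What is called first, only, known or untested is meant among the compounds shown, and "the series" means these compounds.

Measured compounds:
- compound 1 `CCNC(=O)Nc1ccc(-c2nc3n(Cc4c(F)cccc4F)cc(C(=O)OCC)c(=O)n3c2CN(CC(=O)NCc2cn(CCOCCOCCOCCOCCN=[N+]=[N-])nn2)Cc2ccccc2)cc1`: 832 nM
- compound 2 `CCNC(=O)Nc1ccc(-c2nc3n(Cc4c(F)cccc4F)cc(C(=O)OCC)c(=O)n3c2CN(CC(=O)NCc2cn(CCN=[N+]=[N-])nn2)Cc2ccccc2)cc1`: 724 nM
- compound 3 `CCNC(=O)Nc1ccc(-c2nc3n(Cc4c(F)cccc4F)cc(C(=O)NCc4cn(CCOCCOCCN=[N+]=[N-])nn4)c(=O)n3c2CN(C)Cc2ccccc2)cc1`: < 10000 nM

Working notes. In a functional assay on CHO cells for antagonist activity at Gonadotropin-releasing hormone receptor (Homo sapiens), read by a luciferase reporter, with a stated time of 30 min (on this read-out lower numbers stand for stronger inhibition and higher numbers for weaker inhibition), compound 1 gives 832 nM and compound 2 gives 724 nM; these two values lie within the scatter of each other, so the long linker and the short one at the amide position read the same. For compound 3 the assay reports only a limit, < 10000 nM, as noted in the limit of < 10000 nM in this assay, at which 1 of the 3 values shown sits; compound 3 therefore stands apart from compound 1 and compound 2 only in that no number is known for it.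

Compound 4 `CCNC(=O)Nc1ccc(-c2nc3n(Cc4c(F)cccc4F)cc(C(=O)NCc4cn(CCN=[N+]=[N-])nn4)c(=O)n3c2CN(C)Cc2ccccc2)cc1` is the next member. It differs from compound 3 by azido in place of 2-(2-azidoethoxy)ethoxy on a saturated chain carbon, two bonds along the chain from an aromatic nitrogen. The pair compound 1 and compound 2 shows that shortening the chain on the azide side leaves the read-out in this assay within scatter, and the same is expected here: the step from compound 3 to compound 4 is estimated as a step that the limit leaves unreadable from compound 3 to compound 4, no shift beyond the scatter. Compound 4 is thus expected to give about 3000 nM in this assay, with a range from 500 nM to 10000 nM, and a fair chance that again only a limit is reported.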

Compound 4, half-maximal inhibitory concentration: < 10000 nM
Compound 4: no number, only a limit (the forecaster's own chance of this, stated with the estimate: 40%); the middle value lies beyond the limit too.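

In this assay compound 3 and compound 4 each carry only a limit, so no step between them can be read: the limit of < 10000 nM in this assay, at which 2 of the 4 values shown sit.

The compounds shown leave open whether azido in place of 2-(2-azidoethoxy)ethoxy changes the read-out at all in this pair.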